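A few compounds are considered here, and "the series" means these few. Any claim that something is new, unique, unknown or untested is made for them only; others in the source may bear on it.

Among the measured compounds shown here, compound 3 `Cc1ccc(S(=O)(=O)NCc2ccc(CNC(=O)c3ccccc3F)cc2)cc1` stands at the high end of the three numbers known from an assay on MDA-MB-231 cells for binding affinity to C-X-C chemokine receptor type 4 (Homo sapiens), read by immunofluorescence and microscopy, with stated times of 10 min and 30 min; on this read-out lower numbers stand for an effect already at smaller amounts and higher numbers for an effect only at larger amounts of compound: compound 3 gives 1000 nM, while compound 1 `COc1ccc(C(=O)NCc2ccc(CNS(=O)(=O)c3ccc(C)cc3)cc2)cc1` gives 100 nM and compound 2 `Cc1ccc(S(=O)(=O)NCc2ccc(CNC(=O)c3cccc(Cl)c3)cc2)cc1` gives 100 nM. The steps of a 10-fold higher number from compound 1 to compound 3 (1.00 log units; beyond the scatter) and a 10-fold higher number from compound 2 to compound 3 (1.00 log units; beyond the scatter) both lie beyond the scatter, whereas no change at the digits printed from compound 1 to compound 2 (within the scatter). Compound 4 `Cc1ccc(S(=O)(=O)NCc2ccc(CNC(=O)c3cccnc3)cc2)cc1` has not yet been measured in this assay; it differs from compound 3 by pyridin-3-yl in place of 2-fluorophenyl on a carbonyl carbon. For the measured compounds named here, no measured step exchanges a 2-fluorophenyl for a pyridin-3-yl, so the two steps into compound 3 bear on the change only indirectly: compound 1 and compound 2, each carrying a different ring on the carbonyl carbon, sit at the same number, and only the 2-fluorophenyl of compound 3 lies apart. That group leaves in the change to compound 4, and compound 4 is expected to move part of the way back, a 3.3-fold lower number from compound 3 to compound 4 (0.52 log units; beyond the scatter), with the direction more certain than the size. Compound 4 is accordingly estimated at 300 nM, within a range from 50 nM to 2000 nM.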

Compound 4, effective concentration (reported as EC, without a stated level of effect): > 1000 nM
Compound 4 gave a limit, no number; the forecaster's own chance of this, stated with the estimate: 10%; middle value at least 3.3-fold (0.52 log units) away from the limit.
By their numbers in this assay, from the lowest: compounds 1 and 2 (each within the scatter of the next); then compound 3.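

In this assay compound 4 gives > 1000 nM, which is a limit of the assay and not a number. At this place on the carbonyl carbon, pyridin-3-yl does not restore the lower numbers seen with 4-methoxyphenyl and 3-chlorophenyl, with an at least 10-fold higher number from compound 1 to compound 4 (1.00 log units; beyond the scatter) and an at least 10-fold higher number from compound 2 to compound 4 (1.00 log units; beyond the scatter), so a ring with a hetero atom and a hydrogen-bond acceptor joins 2-fluorophenyl on the high side. Pyridin-3-yl in place of 2-fluorophenyl gives a number no lower from compound 3 to compound 4 (the limit leaves the size open) and the size of this step cannot be read, because that result is a limit: the limit of > 1000 nM in this assay, at which 1 of the 4 values shown sits.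

The compounds shown leave open how far compound 4 lies from compound 3, if at all. They also leave open whether pyridin-4-yl, or a phenyl ring carrying an amine or a carboxylic acid, would fall with the lower or the higher compounds.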